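The source may report more compounds than this note shows. Statements on the series, on what has been measured and on what is new or still open speak of the compounds shown alone.

In an ADME assay on cells (Hepatocyte, Homo sapiens) for metabolic stability (a lower number here means that the compound disappears faster, a higher number that the compound lasts longer), compound 2 (`N#Cc1ccc(N2CCC(C(=O)N3N=CC[C@H]3c3cc(F)cc(F)c3)CC2)nn1`) stands at > 8 h, which is a limit and not a number. Compound 4 (`N#Cc1cc(N2CCC(C(=O)N3N=CC[C@H]3c3cc(F)cc(F)c3)CC2)ncn1`) has the same atoms joined differently: a group of 8 heavy atoms (5 carbon, 3 nitrogen; one six-membered aromatic ring with 2 hetero atoms) in place of a group of 8 heavy atoms (5 carbon, 3 nitrogen; one six-membered aromatic ring with 2 hetero atoms), on an amine nitrogen in a ring.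

Two further compounds bear on this change. Compound 1 (`O=C(C1CCN(c2ncccn2)CC1)N1N=CC[C@H]1c1ccccc1`) gives > 3.11 h, which is also a limit. Compound 3 (`O=C(C1CCN(c2ccncn2)CC1)N1N=CC[C@H]1c1ccccc1`) gives 3.3 h. Within the data shown here, the one measured step of a related kind, with pyrimidin-4-yl in place of pyrimidin-2-yl, is a step that the limit leaves unreadable from compound 1 to compound 3, so it supplies no size to carry over. Neither compound 1 nor compound 3 shares the group that leaves or enters here, and no direction can be drawn from them.

The estimated step, an at least 1.1-fold lower number from compound 2 to compound 4 (0.05 log units; that floor lies within the scatter), is therefore expected to stay within the scatter. The number for compound 3, 3.3 h, serves as a guide to the lower side of the range. For compound 4 the expected half-life in this assay is estimated at 7 h, with a range of 3.5 h to 14 h.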

Compound 4, half-life: 3.3 h
Beside the measured number, compound 4's estimate is 2.1-fold (0.33 log units) above it, and the stated range ends above it.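

The change gives an at least 2.4-fold lower number from compound 2 to compound 4 (0.38 log units; beyond the scatter) in this assay, so the two groups on the amine nitrogen in a ring are not interchangeable here, even though they have the same heavy atoms, triple bond and hydrogen-bond acceptor count. The result for compound 2 is a limit and not a number, and the step therefore has only a floor: the limit of > 8 h in this assay, at which 1 of the 4 values shown sits.

The other step shown, between compound 1 and compound 3, cannot be read, which leaves this as the only readable step at this position.

As far as these compounds go, the full size of the step remains open, as does whether the same rearrangement of atoms would give a similar step on the core of compound 1. Also open, from the compounds shown here alone, is how a carboxylic acid or a primary amine in place of the nitrile would stand in this assay.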